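The compounds below may be only part of what the source reports. "The series", "measured", "known", "first", "only" and "open" are said of these compounds alone.

Compound 3 `COc1ccc(C(=O)Nc2cccc(S(=O)(=O)C3CCCC3)n2)c(N2CCC3(CC2)CC3)c1` gives no number in an ADME assay on microsomes from liver (Homo sapiens) for metabolic stability, read by LC-MS, with a stated time of 40 min, tested at 0.5 uM (on this read-out lower numbers stand for slow clearance and higher numbers for fast clearance), only a limit: > 399 mL.min-1.g-1. Compound 2 `CC(C)(O)CNc1ccc(C(=O)Nc2cccc(S(=O)(=O)C3CCCC3)n2)c(N2CCC3(CC2)CC3)c1`, with (2-hydroxy-2-methylpropyl)amino on the same aromatic carbon, also gives only a limit: > 399 mL.min-1.g-1. The series data therefore gather at the limit of > 399 mL.min-1.g-1 in this assay, at which 2 of the 3 values shown sit. Among the compounds with values here, the only numerical reading comes from compound 1 `CC(C)(C)NS(=O)(=O)c1cccc(NC(=O)c2ccc(NC3(CO)CC3)cc2N2CCC3(CC2)CC3)n1`, at 83 mL.min-1.g-1, but compound 1 differs from compound 3 in more than one place.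

Compound 4 `O=C(Nc1cccc(S(=O)(=O)C2CCCC2)n1)c1ccc(NCCO)cc1N1CCC2(CC1)CC2` carries (2-hydroxyethyl)amino in place of methoxy on an aromatic carbon. Within the data shown here, the one measured step at this place is a step that the two limits leave unreadable from compound 2 to compound 3, and it provides no size to carry over. Compound 2 is the closest comparison, and its reading of > 399 mL.min-1.g-1 points to fast clearance for compound 4, possibly another limit. The expected outcome is an at least 1.2-fold lower number from compound 3 to compound 4 (0.09 log units; that floor lies within the scatter), with no firm direction estimated beyond the scatter. For compound 4 the estimate is 320 mL.min-1.g-1, with the expected range running from 140 mL.min-1.g-1 to 700 mL.min-1.g-1.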

Compound 4, intrinsic clearance in microsomes: > 399 mL.min-1.g-1
Compound 4 gave a limit, no number; the forecaster's own chance of this, stated with the estimate: 45%; middle value at least 1.2-fold (0.09 log units) from the limit.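

Compound 4, like compound 2 and compound 3, gives only a limit and no number, so no step among these three can be read: the limit of > 399 mL.min-1.g-1 in this assay, at which 3 of the 4 values shown sit. The compounds shown leave open whether any group on this aromatic carbon changes the clearance in this assay.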